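The source may hold more compounds than are shown below. What is called first, only, known or untested is meant among the compounds shown, and "the series" means these compounds.

Among the measured compounds shown here, in a functional assay on MCF7 cells (Homo sapiens) for cytotoxicity, read by MTT assay, with a stated time of 48 h (a lower number here means a stronger inhibitor, a higher number a weaker inhibitor), compound 1 `COc1cc(/C=C/C(=O)/C=C/c2nc3cc(C)ccc3n2C)ccc1O` gives 4500 nM, the lower of the two numbers measured so far. Compound 2 `COc1cc(/C=C/C(=O)/C=C/c2nc3c(C)c(C)ccc3n2C)ccc1O` gives 14100 nM. Compound 3 `COc1cc(/C=C/C(=O)/C=C/c2nc3cc(O)ccc3n2C)ccc1O` has not yet been measured. It differs from compound 1 by hydroxy in place of methyl on an aromatic carbon, part of a fused or bridged system of two rings: hydroxy in place of methyl on an aromatic carbon. For the measured compounds named here, only one measured step bears on this change, and only indirectly. That step is a 3.1-fold higher number from compound 1 to compound 2 (0.50 log units; beyond the scatter), a modest move beyond the scatter, which comes from methyl in place of hydrogen on an aromatic carbon. Going by the values given here, it shows that a small change on an aromatic carbon of the core can shift the number, but no measured compound carries hydroxy at this place, so the direction remains open. A modest step in this assay is therefore expected, leaning slightly towards a higher number. The expected step is a 1.3-fold higher number from compound 1 to compound 3 (0.12 log units; within the scatter). For compound 3 the estimated value is 6000 nM, with an expected range from 2000 nM to 18000 nM.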

Compound 3, half-maximal inhibitory concentration: 2900 nM
Compound 3: the middle estimate sits 2.1-fold (0.32 log units) above what was measured; low and high end bracket the measured number.
By their numbers in this assay, from the lowest: compounds 3 and 1 (each within the scatter of the next); then compound 2.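

In this assay, the exchange at this aromatic carbon, meta to a fused ring and para to a fused ring, gives a 1.6-fold lower number from compound 1 to compound 3 (0.19 log units; within the scatter), so methyl and hydroxy cannot be told apart here, although hydroxy counts 1 hydrogen-bond donor and 1 hydrogen-bond acceptor where methyl counts 0. Among the compounds shown here, the only earlier step on the shared core, a 3.1-fold higher number from compound 1 to compound 2 (0.50 log units; beyond the scatter), was methyl in place of hydrogen on an aromatic carbon, and it lay beyond the scatter, so a change on this ring does not always move the number beyond the scatter. Nothing at hand gives a reason for this result.

Going by these compounds, whether a methoxy group, an amine or a carboxylic acid at this same carbon would also stay within the scatter of compound 1 remains open. On these data alone, it is also open whether hydroxy on another aromatic carbon of the core, or hydroxy together with the added methyl of compound 2, would give a number close to that of compound 3.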